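This account rests on a few compounds, and the source may have more. Where it says the series, first, only, none or still open, it means among the compounds named here.

Compound 1 `CC(C)(Sc1ccccc1)C1OCC(C/C=C\CCC(=O)O)C(c2cccnc2)O1` gives 40 nM in an assay for inhibition of Thromboxane-A synthase (Homo sapiens), using microsomes; on this read-out higher numbers stand for weaker inhibition and lower numbers for stronger inhibition. Compound 2 `Cc1ccc(SC(C)(C)C2OCC(C/C=C\CCC(=O)O)C(c3cccnc3)O2)c([N+](=O)[O-])c1` gives 30 nM in this assay, and it sits alongside compound 1, since the step of a 1.3-fold lower number from compound 1 to compound 2 (0.12 log units; within the scatter) is within the scatter. Compound 3 `COc1ccc(SC(C)(C)C2OCC(C/C=C\CCC(=O)O)C(c3cccnc3)O2)c([N+](=O)[O-])c1` differs from compound 2 by methoxy in place of methyl on an aromatic carbon. Within the data shown here, no measured step exchanges a methyl for a methoxy; the only step touching this part of the molecule, a 1.3-fold lower number from compound 1 to compound 2 (0.12 log units; within the scatter), stayed within the scatter, so no step beyond the scatter is expected in this assay. Compound 3 is therefore estimated at 30 nM, between 12 nM and 80 nM, an expected step of no change at the digits printed from compound 2 to compound 3 (within the scatter).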

Compound 3, half-maximal inhibitory concentration: 40 nM
Compound 3: the middle estimate sits 1.3-fold (0.12 log units) below what was measured; measured number inside the range.
By their numbers in this assay, from the lowest: compounds 2, 1 and 3 (each within the scatter of the next).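

In this assay, methoxy in place of methyl, para to a large group, gives a 1.3-fold higher number from compound 2 to compound 3 (0.12 log units; within the scatter) and so adds a hydrogen-bond acceptor at this position without a step beyond the scatter. The 4-methoxy-2-nitrophenyl group in place of phenyl on the sulfur gives no change at the digits printed from compound 1 to compound 3 (within the scatter) and so stands level with the phenyl of compound 1. No supporting evidence bears on this result.

From the compounds shown here alone, whether an amine or a longer chain such as ethoxy at this position would also stay within the scatter remains open. So does the contribution of the nitro group alone, as compound 2 and compound 3 both carry it.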